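Varying the pyridine substituent on a shared oxadiazole-amide core

The source may hold more compounds than are shown below. What is called first, only, known or untested is meant among the compounds shown, and "the series" means these compounds.

Measured so far in an assay on T-REx-293 cells for inhibition of potassium channel subfamily T member 1 (Homo sapiens), read by patch clamp; on this read-out lower numbers stand for stronger inhibition and higher numbers for weaker inhibition:
compound 1 `Cc1cccc(-c2noc([C@H](C)NC(=O)c3cc(C(F)(F)F)nn3C)n2)n1`: > 30000 nM
compound 2 `C[C@H](NC(=O)c1cc(C(F)(F)F)nn1C)c1nc(-c2ccnc(N3CCCC3)c2)no1`: 573 nM
compound 3 `COc1cc(-c2noc([C@H](C)NC(=O)c3cc(C(F)(F)F)nn3C)n2)cc(C)n1`: 505 nM.

Compound 1 gives a limit of this assay, not a number. Compound 3 gives the lowest of the two numbers shown, and compound 2 sits within the scatter of it. For the measured compounds named here, the one step with a number, an at least 59-fold lower number from compound 1 to compound 3 (1.77 log units; beyond the scatter), concerns a different change and is marked by the limit of > 30000 nM in this assay, at which 1 of the 3 values shown sits.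

Compound 4 `CO[C@H](C)c1cc(-c2noc([C@H](C)NC(=O)c3cc(C(F)(F)F)nn3C)n2)ccn1` differs from compound 3 by a group of 10 heavy atoms (8 carbon, 1 nitrogen, 1 oxygen; one six-membered aromatic ring with 1 hetero atom) in place of a group of 9 heavy atoms (7 carbon, 1 nitrogen, 1 oxygen; one six-membered aromatic ring with 1 hetero atom), on an aromatic carbon. Going by the values given here, no measured step bears directly on this change; compound 2 and compound 3 only show that two different groups at this position give close numbers. Compound 4 is therefore expected to stay near compound 3, with a step of a 1.3-fold higher number from compound 3 to compound 4 (0.11 log units; within the scatter) in this assay, and its estimated value is 650 nM, between 200 nM and 2500 nM.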

Compound 4, half-maximal inhibitory concentration: 778 nM
Compound 4: middle estimate off by 1.2-fold (0.08 log units), on the low side, and the stated range covers the measured number.
By their numbers in this assay, from the lowest: compounds 3, 2 and 4 (each within the scatter of the next). At a limit, above all of these: compound 1.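

In this assay, 1-methoxyethyl in place of pyrrolidin-1-yl gives a 1.4-fold higher number from compound 2 to compound 4 (0.13 log units; within the scatter), and the group of compound 4 in place of 2-methoxy-6-methylpyridin-4-yl gives a 1.5-fold higher number from compound 3 to compound 4 (0.19 log units; within the scatter). A third group carrying a defined stereocentre thus joins the other two within the scatter at this position. The gap to the core of compound 1 also holds, with an at least 38-fold lower number from compound 1 to compound 4 (1.58 log units; beyond the scatter), though that step rests on a limit: the limit of > 30000 nM in this assay, at which 1 of the 4 values shown sits.

As far as these compounds go, whether an amine, a carboxylic acid or a longer alkoxy chain here would give similar numbers stays open. So does how the opposite stereocentre of the 1-methoxyethyl group would read.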